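The source may report more compounds than this note shows. Statements on the series, on what has been measured and on what is new or still open speak of the compounds shown alone.

In a functional assay on CHO cells with adenosine receptor A1 (Homo sapiens) as the target, read by cAMP accumulation and immunoassay, with a stated time of 6 min, tested at 0.1 uM (a lower number here means a stronger effect, a higher number a weaker effect of the compound at the concentration tested), the measured compounds gave the following:

compound 1, `CC(C)N1CCN(Cc2csc(N)c2C(=O)c2ccc(Cl)cc2)CC1`: 3.6%
compound 2, `COc1ccc(N2CCN(Cc3csc(N)c3C(=O)c3ccc(Cl)cc3)CC2)cc1`: 0%
compound 3, `Nc1scc(CN2CCN(c3cccnc3)CC2)c1C(=O)c1ccc(Cl)cc1`: 3.4%

Compound 2 stands lowest of the three, yet both the step of a number 3.6 percentage points lower from compound 1 to compound 2 (within the scatter) and the step of a number 3.4 percentage points higher from compound 2 to compound 3 (within the scatter) lie within the scatter, so the three compounds cannot be told apart. Compound 4, `Nc1scc(CN2CCN(c3ccncc3)CC2)c1C(=O)c1ccc(Cl)cc1`, differs from compound 2 by pyridin-4-yl in place of 4-methoxyphenyl on an amine nitrogen in a ring. The step that bears most directly on this is a number 3.4 percentage points higher from compound 2 to compound 3 (within the scatter), a change of the same kind at the same place; the steps of a number 3.6 percentage points lower from compound 1 to compound 2 (within the scatter) and a number 0.2 percentage points lower from compound 1 to compound 3 (within the scatter) also show that exchanging the group on this ring nitrogen moved nothing beyond the scatter. Compound 4 is therefore expected to show a number 2 percentage points higher from compound 2 to compound 4 (within the scatter). The estimate for compound 4 is 2%, within -5% to 9%.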

Compound 4, a percentage reported as activity, at one concentration (the size of the read-out at that concentration, not a potency): 1.4%
For compound 4 the middle estimate is 0.6 percentage points above the measured one; measured number inside the range.
By their numbers in this assay, from the lowest: compounds 2, 4, 3 and 1 (each within the scatter of the next).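

In this assay, pyridin-4-yl in place of pyridin-3-yl gives a number 2 percentage points lower from compound 3 to compound 4 (within the scatter), so this exchange within the aromatic ring makes no difference that can be read. The replacements of 4-methoxyphenyl and isopropyl by pyridin-4-yl give a number 1.4 percentage points higher from compound 2 to compound 4 (within the scatter) and a number 2.2 percentage points lower from compound 1 to compound 4 (within the scatter), which extends the flat picture on this ring nitrogen to a fourth group. Nothing available explains this lack of difference.

From the compounds shown here alone, whether a carboxylic acid or a longer chain ending in an amine at this place would give a step beyond the scatter remains open. A read-out at one concentration also leaves the potencies of these compounds open.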